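The source may report more compounds than this note shows. Statements on the series, on what has been measured and on what is new or still open speak of the compounds shown alone.

Measured compounds:
Compound 1 `CO[C@H]1C[C@H](O[Si](C)(C)C(C)(C)C)O[C@@H](C)/C1=C\C=N\O`, 0.002 ug/mL
Compound 2 `CO[C@H]1C[C@H](O[Si](C)(C)C(C)(C)C)O[C@@H](C)/C1=C\C(=O)O`, 0.002 ug/mL
Compound 3 `CO[C@H]1C[C@H](O[Si](C)(C)C(C)(C)C)O[C@@H](C)/C1=C/CO`, 0.01 ug/mL

In a functional assay on the whole organism for inhibition, with Artemia salina as the target (a lower number here means a stronger inhibitor of growth, a higher number a weaker inhibitor of growth), compound 3 stands highest of the three, its number lying beyond the scatter from both compound 1 and compound 2, which sit together. Compound 4 `CO[C@H]1C[C@H](O[Si](C)(C)C(C)(C)C)O[C@@H](C)/C1=C/CCl` differs from compound 3 by chloro in place of hydroxy on a saturated chain carbon bound to a double-bonded chain carbon. Among the measured compounds shown here, the only step on record, no change at the digits printed from compound 1 to compound 2 (within the scatter), concerns the group on the double-bonded chain carbon and not the saturated chain carbon touched here, so no measured step bears on this change, and the data give no guide to its direction. The step from compound 3 to compound 4 is therefore estimated as no change at the digits printed from compound 3 to compound 4 (within the scatter), with wide uncertainty. Compound 4 is expected to give 0.01 ug/mL, between 0.0025 ug/mL and 0.04 ug/mL.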

Compound 4, minimum inhibitory concentration: 0.01 ug/mL
Compound 4: the middle estimate sits on the measured number at the digits printed, and the stated range covers the measured number.
By their numbers in this assay, from the lowest: compounds 1 and 2 (each within the scatter of the next); then compounds 3 and 4 (each within the scatter of the next).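

In this assay, chloro in place of hydroxy on a saturated chain carbon bound to a double-bonded chain carbon gives no change at the digits printed from compound 3 to compound 4 (within the scatter), the first step read at this position. Losing the hydrogen-bond donor and acceptor counted on hydroxy thus leaves the number within the scatter in this one pair. No measurement shown here accounts for this result. From the compounds shown here alone, whether an amine, a methoxy group or a longer chain on that carbon would keep the number within the scatter remains open. So does whether fluoro or bromo would behave as chloro does.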